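The source may report more compounds than this note shows. Statements on the series, on what has been measured and on what is new or still open speak of the compounds shown alone.

Measured compounds:
compound 1, `COc1ccc(-c2cc(/C=C/C(=O)c3ccc(N)cc3)[nH]n2)cc1` — 96%
compound 2, `COc1cc(-c2cc(/C=C/C(=O)c3ccc(N)cc3)[nH]n2)cc(OC)c1OC` — 100%

Of the compounds shown here, two have been measured in a functional assay on OVCAR-8 cells (Homo sapiens) for cytotoxicity, read by sulforhodamine B assay, with a stated time of 48 h, tested at 0.01 uM; a lower number here means a stronger effect, a higher number a weaker effect of the compound at the concentration tested. In this assay compound 2 gives 100%, the higher of the two numbers, while compound 1 gives 96%; the gap between the two lies within the scatter of repeated measurements, so the two cannot be ranked against each other, and both show little effect at the concentration tested.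

The account now turns to compound 3, `COc1ccc(-c2cc(/C=C/C(=O)c3ccc(N)cc3)[nH]n2)cc1OC`, which has not yet been measured in this assay. Compared with compound 2, the change is hydrogen in place of methoxy on an aromatic carbon: a methoxy leaves and a hydrogen enters on an aromatic carbon of a six-membered aromatic ring of carbon only, ortho to a methoxy group and meta to a large group.

Among the measured compounds shown here, no step between measured compounds is available to guide the expectation. Since compound 1, with a single methoxy on that ring, and compound 2, with three, sit within the scatter of one another, the step of a number 2 percentage points lower from compound 2 to compound 3 (within the scatter) is expected to be none beyond the scatter. Compound 3 is therefore estimated at 98%, within a range from 88% to 108%.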

Compound 3, a percentage reported as activity, at one concentration (the size of the read-out at that concentration, not a potency): 98%
The estimate for compound 3 equals the measured number at the digits printed; the measured number falls inside the stated range.
By their numbers in this assay, from the lowest: compounds 1, 3 and 2 (each within the scatter of the next).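

In this assay, hydrogen in place of methoxy on an aromatic carbon comes with a number 2 percentage points lower from compound 2 to compound 3 (within the scatter) and methoxy in place of hydrogen on an aromatic carbon comes with a number 2 percentage points higher from compound 1 to compound 3 (within the scatter) as the matching step from the other side. Compounds 1 and 2 differ by more than one methoxy, so they could not speak to a single group, whereas these steps each isolate one methoxy on the aromatic ring and show that neither change moves the read-out beyond the scatter at this one concentration. No further measurement is at hand that bears on this result.

The three compounds leave open whether a different group on this aromatic carbon, such as a hydroxyl, a fluorine or an amine, would shift the read-out at this concentration, and whether replacing the amine on the other aromatic ring with an amide or a nitrile would do so. They also leave open whether the methoxy groups would matter at a higher concentration, where the read-out might differ from the values seen here.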